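Methoxy removal on the biaryl in the urea series

The compounds below may be only part of what the source reports. "The series", "measured", "known", "first", "only" and "open" are said of these compounds alone.

Measured so far:
- compound 1 `COc1ccccc1-c1ccc(CNC(=O)NC2CCN(Cc3ccc(C)cc3)CC2)cc1` — 99.5%
- compound 2 `Cc1ccc(CN2CCC(NC(=O)NCc3ccc(-c4ccccc4)cc3)CC2)cc1` — 124%
- compound 3 `COc1ccc(-c2ccc(CN(CCC3CCN(Cc4ccc(C)cc4)CC3)C(=O)NC(C)(C)COC(C)=O)cc2)cc1` — 112%

In an in vitro functional assay on HEK293 cells for antagonist activity at melanin-concentrating hormone receptor 1 (Homo sapiens) (a lower number here means a smaller maximal response, a higher number a larger maximal response), compound 1 gives 99.5% and compound 2 gives 124%. The change between them is hydrogen in place of methoxy on an aromatic carbon, and the step is a number 24.5 percentage points higher from compound 1 to compound 2 (beyond the scatter). Compound 3 gives 112% in this assay; how the core of compound 3 differs from the core of compound 1 is not broken down here. Compound 4 `CC(=O)OCC(C)(C)NC(=O)N(CCC1CCN(Cc2ccc(C)cc2)CC1)Cc1ccc(-c2ccccc2)cc1` is not yet measured. It differs from compound 3 by hydrogen in place of methoxy on an aromatic carbon. This is the same kind of change as from compound 1 to compound 2, but the place is not the same: in compound 1 the methoxy sits ortho to a large group, in compound 3 para to a large group, so the earlier step is only a loose guide. An increase is expected, a number 13 percentage points higher from compound 3 to compound 4 (beyond the scatter), smaller than the measured step because of a number 24.5 percentage points higher from compound 1 to compound 2 (beyond the scatter) on a different core. Compound 4 is estimated at 125%, between 105% and 145%.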

Compound 4, largest response reached (reported as Imax), in percent of the reference or control that the assay uses: 102%
Compound 4: the middle estimate sits 23 percentage points above what was measured, outside the stated range (below it).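

Hydrogen in place of methoxy gives a number 10 percentage points lower from compound 3 to compound 4 (within the scatter) in this assay, so the rise seen on the core of compound 1 does not recur on the core of compound 3. The two steps differ: the same change on two cores in this assay, a number 24.5 percentage points higher (beyond the scatter) from compound 1 to compound 2 and a number 10 percentage points lower (within the scatter) from compound 3 to compound 4, 34.5 percentage points apart, beyond the scatter of two such steps. The change therefore cannot be carried from one of these cores to the other as a fixed increment, but what separates the two steps remains unresolved, as the place of the methoxy and the core differ at once, and two pairs give no rule for the series.

Open, going by these compounds, is whether the steps would match with the methoxy in the same place on both cores. Also open, on these data alone, is how a fluorine atom, a hydroxyl or a nitrile on this aromatic carbon would behave on either core.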